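Chlorine position on the benzyl arm and arterial inhibition

The compounds below may be only part of what the source reports. "The series", "measured", "known", "first", "only" and "open" are said of these compounds alone.

Measured compounds:
compound 1, `CC1=C(C(=O)Nc2ccc(F)cc2)C(c2ccc([N+](=O)[O-])cc2)N=C(SCc2cccc(Cl)c2)N1`: 16.4%
compound 2, `CC1=C(C(=O)Nc2ccc(F)cc2)C(c2ccc([N+](=O)[O-])cc2)N=C(SCc2ccc(Cl)cc2)N1`: 28.2%
compound 3, `CC1=C(C(=O)Nc2ccc([N+](=O)[O-])cc2)C(c2ccc(Br)cc2)N=C(SCc2cccc(Cl)c2)N1`: 5.1%

Three compounds of one series were tested in a functional assay on the whole organism (artery, strain albino) with Rattus norvegicus as the target, with a stated time of 600 min, at a dose of 10 mg/kg by the oral route; on this read-out higher numbers stand for more inhibition at the one dose given (going by the name of the read-out) and lower numbers for less inhibition. Compound 1 and compound 2 share a core and differ in one place: 4-chlorophenyl in place of 3-chlorophenyl on a saturated chain carbon bound to a sulfur. On this change the read-out moved a number 11.8 percentage points higher from compound 1 to compound 2 (beyond the scatter), a step beyond the scatter of the assay. Compound 3 carries the same pendant group as compound 1 but a different core; how the two cores differ is not broken down here, and compound 3 is the lowest of the three in this assay, with compound 1 nearest to it.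

Compound 4, `CC1=C(C(=O)Nc2ccc([N+](=O)[O-])cc2)C(c2ccc(Br)cc2)N=C(SCc2ccc(Cl)cc2)N1`, is not yet measured. It arises from compound 3 by the same change: 4-chlorophenyl in place of 3-chlorophenyl on a saturated chain carbon bound to a sulfur. Since this is the same change that raised the read-out from compound 1 to compound 2, compound 4 is expected to lie above compound 3 by roughly a step of a number 9.9 percentage points higher from compound 3 to compound 4 (within the scatter). Going by the values given here, the estimate for compound 4 in this assay is 15%, expected to fall between 3% and 30%, and it rests only on the single earlier pair, because the step of a number 11.8 percentage points higher from compound 1 to compound 2 (beyond the scatter) is the one precedent.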

Compound 4, a percentage reported as inhibition, in the whole organism at one dose (the size of the read-out at that dose, not a potency): 34.4%
The estimate for compound 4 lay 19.4 percentage points below the measured number; measured number above the stated range.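

In this assay, 4-chlorophenyl in place of 3-chlorophenyl on a saturated chain carbon bound to a sulfur went in the same direction on the second core, giving a number 29.3 percentage points higher from compound 3 to compound 4 (beyond the scatter). The direction of the change carried over from one core to the other, but its size did not: the same change on two cores in this assay, a number 11.8 percentage points higher (beyond the scatter) from compound 1 to compound 2 and a number 29.3 percentage points higher (beyond the scatter) from compound 3 to compound 4, 17.5 percentage points apart, beyond the scatter of two such steps

These two pairs cannot show which part of the cores goes with the larger step, nor whether the direction would hold on a third core, and as readings at one dose they say nothing about potency.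

The compounds shown leave open how a plain phenyl, a 4-methoxyphenyl or a longer chain on the sulfur would compare with 4-chlorophenyl. They also leave open whether the size of the step follows the group on the amide nitrogen or the other aryl group of the core, which a core changed in only one of these places could separate.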